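This account rests on a few compounds, and the source may have more. Where it says the series, first, only, none or still open, it means among the compounds named here.

Compounds measured in an ADME assay on NIH3T3 cells (Mus musculus) for cytotoxicity, read by XTT assay, with a stated time of 24 h; on this read-out higher numbers stand for weaker inhibition and lower numbers for stronger inhibition:

- compound 1 `Cn1nnnc1SCC(=O)N/N=C/c1cccc(F)c1` gives 6320000 nM
- compound 2 `Cn1nnnc1SCC(=O)N/N=C/c1ccccc1Cl` gives only a limit of the assay, > 10000000 nM
- compound 3 `Cn1nnnc1SCC(=O)N/N=C/c1ccccc1O` gives only a limit of the assay, > 10000000 nM

Among the measured compounds shown here, compound 1 is the only member of the series with a number in this assay; compounds 2 and 3 sit at the limit of > 10000000 nM in this assay, at which 2 of the 3 values shown sit. Compound 4 `Cc1cccc(/C=N/NC(=O)CSc2nnnn2C)c1` differs from compound 1 by methyl in place of fluoro on an aromatic carbon. For the measured compounds named here, no measured step touches this change. Going by the values given here, the single measured step, a step that the two limits leave unreadable from compound 2 to compound 3, runs between two limits and gives no size. With nothing to read, no step beyond the scatter is expected for compound 4, and the estimated step of a 1.1-fold higher number from compound 1 to compound 4 (0.04 log units; within the scatter) stays flat. Compound 4 is therefore expected at 7000000 nM, between 2500000 nM and 20000000 nM, with a real chance that only a limit is reported.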

Compound 4, half-maximal inhibitory concentration: 6250000 nM
The estimate for compound 4 lay 1.1-fold (0.05 log units) above the measured number; low and high end bracket the measured number.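

In this assay, methyl in place of fluoro on an aromatic carbon, meta to a large group, gives a 1.0-fold lower number from compound 1 to compound 4 (0.00 log units; within the scatter). Among the compounds shown here, the only earlier step cannot be read; this is the first readable step, and at this position the two groups are not told apart on this read-out. Compound 2 and compound 3 give only a limit of the assay: the limit of > 10000000 nM in this assay, at which 2 of the 4 values shown sit.

On these data alone, whether an amine or a carboxylic acid at this position would give a step beyond the scatter stays open. So does the effect of a longer chain there.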